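Swapping hydroxy for fluoro on the aromatic ring

The source may report more compounds than this note shows. Statements on the series, on what has been measured and on what is new or still open speak of the compounds shown alone.

Compound 1 `COc1ccc(-n2cnnc2-c2cc(OC)c(OC)c(OC)c2)cc1` gives 1290 nM
Compound 2 `COc1ccc(-n2cnnc2-c2cc(OC)c(OC)c(OC)c2)cc1O` gives 302 nM

In a functional assay on SF-295 cells (Homo sapiens) for inhibition (on this read-out higher numbers stand for weaker inhibition of growth and lower numbers for stronger inhibition of growth), compound 2 stands lowest of the two measured compounds, at 302 nM and so with the stronger inhibition of growth. Compound 3 `COc1ccc(-n2cnnc2-c2cc(OC)c(OC)c(OC)c2)cc1F` has fluoro in place of hydroxy on an aromatic carbon, ortho to a methoxy group, a change counted as fluoro in place of hydroxy on an aromatic carbon with the rest of the structure untouched. Going by the values given here, one measured step bears on this: a 4.3-fold lower number from compound 1 to compound 2 (0.63 log units; beyond the scatter) when hydroxy replaced hydrogen at that same place. Among the compounds with values here, compound 3 loses that hydroxy, and no measured compound carries fluoro, so the size of any change remains uncertain. A partial return towards compound 1 is expected, meaning a higher number in this assay by less than that measured step. The expected size is a 2.2-fold higher number from compound 2 to compound 3 (0.33 log units; beyond the scatter) on this estimate. Compound 3 is estimated at 650 nM (expected range 220 nM to 2000 nM).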

Compound 3, concentration for 50% growth inhibition: 1860 nM
Compound 3: the middle estimate sits 2.9-fold (0.46 log units) below what was measured; low and high end bracket the measured number.
By their numbers in this assay, from the lowest: compound 2; then compounds 1 and 3 (each within the scatter of the next).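

In this assay, the gain that came with hydroxy does not survive the swap to fluoro: the change is a 6.2-fold higher number from compound 2 to compound 3 (0.79 log units; beyond the scatter) and is beyond the scatter. Set against the parent with plain hydrogen at this place, fluoro gives a 1.4-fold higher number from compound 1 to compound 3 (0.16 log units; within the scatter), which lies within the scatter, so among the three groups shown only hydroxy stands apart, and simply filling this place with a single heavy atom does not reproduce its effect. Nothing available here explains why these groups differ.

On these data alone, whether an amine or a carboxylic acid at this place would behave like hydroxy or like fluoro remains open. So does the result of capping the hydroxy as an ethoxy group, which would show whether the free hydrogen of the hydroxy matters.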